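Cyclopentyl on the Ring Amide Nitrogen of Compound 4

The source may report more compounds than this note shows. Statements on the series, on what has been measured and on what is new or still open speak of the compounds shown alone.

In a functional assay on BT-474 cells (Homo sapiens) for inhibition (a lower number here means a stronger inhibitor, a higher number a weaker inhibitor), three compounds of one shared core have been measured. Compound 1 `COc1c(C)cnc(CN2c3nc(N)nc(Cl)c3NC(=O)[C@H]2C)c1C` gives 410 nM. Compound 2 `COc1c(C)cnc(CN2CC(=O)N(C(C)C)c3c(Cl)nc(N)nc32)c1C` gives 30 nM, and compound 3 `COc1c(C)cnc(CN2CC(=O)N(C(C)C(=O)NCCN(C)C)c3c(Cl)nc(N)nc32)c1C` gives 60 nM. Compound 3 thus stands second highest of the three numbers; its nearest neighbour is compound 2, within the scatter of it, and its furthest is compound 1, which lies beyond the scatter from it. Compound 4 `COc1c(C)cnc(CN2CC(=O)N(C3CCCC3)c3c(Cl)nc(N)nc32)c1C` differs from compound 3 in one place: cyclopentyl in place of 1-((2-(dimethylamino)ethyl)carbamoyl)ethyl on an amide-type nitrogen in a ring. For the measured compounds named here, only one measured step touches this position, a 2.0-fold higher number from compound 2 to compound 3 (0.30 log units; within the scatter), where (2-(dimethylamino)ethyl)carbamoyl replaced methyl on the saturated chain carbon bound to that nitrogen. That step stayed within the scatter, so the larger group made little difference to the number. Compound 4 is therefore expected to land near compound 2 and compound 3. The step of a 1.5-fold lower number from compound 3 to compound 4 (0.18 log units; within the scatter) is expected to stay within the scatter. The estimate for compound 4 in this assay is 40 nM, ranging from 15 nM to 120 nM.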

Compound 4, half-maximal inhibitory concentration: 290 nM
Compound 4: the middle estimate sits 7.3-fold (0.86 log units) below what was measured, and the stated range ends below it.
By their numbers in this assay, from the lowest: compounds 2 and 3 (each within the scatter of the next); then compounds 4 and 1 (each within the scatter of the next).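

In this assay, the group on the amide-type nitrogen in a ring proves to matter: cyclopentyl in place of 1-((2-(dimethylamino)ethyl)carbamoyl)ethyl gives a 4.8-fold higher number from compound 3 to compound 4 (0.68 log units; beyond the scatter), and cyclopentyl in place of isopropyl gives a 9.7-fold higher number from compound 2 to compound 4 (0.99 log units; beyond the scatter). Heavy-atom count does not order these numbers, since compound 2 and compound 3 both carry lower numbers than compound 4, although isopropyl has fewer heavy atoms than cyclopentyl and 1-((2-(dimethylamino)ethyl)carbamoyl)ethyl has more. Nothing at hand explains why cyclopentyl behaves differently here.

The compounds shown leave open whether the higher number goes with any ring on this nitrogen or with cyclopentyl alone, which a cyclopropyl group or an open pent-3-yl chain could separate. Going by these compounds, it is also open whether an amine on the cyclopentyl ring would change the number.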